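Methylamino to Dimethylamino on Two Related Cores

This account rests on a few compounds, and the source may have more. Where it says the series, first, only, none or still open, it means among the compounds named here.

Three compounds have been measured in a functional assay on K562 cells (Homo sapiens) for antiproliferative activity, read by CellTiter-Glo and CCK-8 assay, with a stated time of 72 h; on this read-out lower numbers stand for stronger inhibition of growth and higher numbers for weaker inhibition of growth:
compound 1, `CNc1cc(Nc2ncc3c(n2)N(C)C(=O)N(c2cc(NC(=O)c4cccc(C(F)(F)F)c4)ccc2C)C3)ccc1C`, where compound 1 gives 19 nM;
compound 2, `Cc1ccc(Nc2ncc3c(n2)N(C)C(=O)N(c2cc(NC(=O)c4cccc(C(F)(F)F)c4)ccc2C)C3)cc1N(C)C`, where compound 2 gives 28 nM;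
compound 3, `CNc1nc(Nc2ccc(C)c([N+](=O)[O-])c2)ncc1C(=O)Nc1cc(NC(=O)c2cccc(C(F)(F)F)c2)ccc1C`, where compound 3 gives 52 nM.

Compound 2 differs from compound 1 by methyl in place of hydrogen on a nitrogen on an aromatic ring, and this change produced a 1.5-fold higher number from compound 1 to compound 2 (0.17 log units; within the scatter). Compound 3 carries a different core; how the core of compound 1 and the core of compound 3 differ is not broken down here. Compound 3 has the highest number of the three, and its gap to compound 1 lies beyond the scatter, while its gap to compound 2 does not.

Compound 4, `Cc1ccc(NC(=O)c2cccc(C(F)(F)F)c2)cc1NC(=O)c1cnc(Nc2ccc(C)c([N+](=O)[O-])c2)nc1N(C)C`, has not yet been measured in this assay. It stands to compound 3 exactly as compound 2 stands to compound 1: the change is methyl in place of hydrogen on a nitrogen on an aromatic ring, at a place described in the same words, so it is the same change on another core. Compound 4 is expected to show a 1.4-fold higher number from compound 3 to compound 4 (0.16 log units; within the scatter) because the same change gave a 1.5-fold higher number from compound 1 to compound 2 (0.17 log units; within the scatter). For compound 4 the estimate is therefore 75 nM, expected to fall between 30 nM and 200 nM.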

Compound 4, concentration for 50% growth inhibition: > 10000 nM
Compound 4 ended at the assay's limit; the forecaster's own chance of this, stated with the estimate: 2%; middle value at least 130-fold (2.12 log units) away from the limit.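

In this assay compound 4 gives > 10000 nM, which is a limit of the assay and not a number. On the second of the two cores, the change from methylamino to dimethylamino gave an at least 190-fold higher number from compound 3 to compound 4 (2.28 log units; beyond the scatter), so the small step seen on the first core did not carry over: the same change on two cores in this assay, a 1.5-fold higher number (0.17 log units; within the scatter) from compound 1 to compound 2 and an at least 190-fold higher number (2.28 log units; beyond the scatter) from compound 3 to compound 4, at least 130-fold (2.11 log units) apart, beyond the scatter of two such steps This shows that the same change cannot be assumed to behave alike on these two cores, but it does not show what lies behind the gap, and with a limit on one side the true size of the step stays unknown.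

Each core contributes only one pair, so nothing shown says how the change behaves on any further core in the series. The compounds shown also leave open whether a plain amino group or an ethylamino group in the same place would stay close to compound 3 or fall as far as compound 4.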